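Methoxy for Fluoro on the Other Ring

The compounds below may be only part of what the source reports. "The series", "measured", "known", "first", "only" and "open" are said of these compounds alone.

Compound 2 `O=C(/C=C\Nc1ccc(O)cc1)c1cn(-c2ccccc2)nc1-c1ccc(F)cc1` gives 16300 nM in an ADME assay on HaCaT cells (Homo sapiens) for antiproliferative activity, read by MTT assay, with a stated time of 48 h (on this read-out lower numbers stand for stronger inhibition and higher numbers for weaker inhibition), the low end of the two numbers recorded, though compound 3 `COc1ccc(N/C=C\C(=O)c2cn(-c3ccccc3)nc2-c2ccc(F)cc2)cc1` gives 19600 nM and sits within the scatter of it. For compound 1 `O=C(/C=C\Nc1ccc(F)cc1)c1cn(-c2ccccc2)nc1-c1ccc(F)cc1` this assay reports only a limit, > 50000 nM. Compound 4 `COc1ccc(-c2nn(-c3ccccc3)cc2C(=O)/C=C\Nc2ccc(O)cc2)cc1` differs from compound 2 by methoxy in place of fluoro on an aromatic carbon. Among the measured compounds shown here, two measured steps bear on this change: an at least 2.5-fold lower number from compound 1 to compound 3 (0.40 log units; beyond the scatter), and an at least 3.0-fold lower number from compound 1 to compound 2 (0.48 log units; beyond the scatter), though both sat on the other phenyl ring, the one attached to the nitrogen. A modest lowering of the number is therefore expected, held loosely. Compound 4 is estimated at 10000 nM, within 4000 nM to 25000 nM. That estimate would mean a 1.6-fold lower number from compound 2 to compound 4 (0.21 log units; within the scatter).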

Compound 4, half-maximal inhibitory concentration: 34600 nM
Estimate against measurement, compound 4: 3.5-fold (0.54 log units) below; measured number outside the range, above it.
By their numbers in this assay, from the lowest: compounds 2, 3 and 4 (each within the scatter of the next, the first and the last beyond it). At a limit, above all of these: compound 1.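

On the 4-fluorophenyl ring, methoxy in place of fluoro weakens the effect in this assay, giving a 2.1-fold higher number from compound 2 to compound 4 (0.33 log units; beyond the scatter). Compound 1 has only a limit, > 50000 nM. The same swap therefore does not carry over from one place to the other, and its direction here could not be read from the earlier compounds: the same change on two cores in this assay, an at least 2.5-fold lower number (0.40 log units; beyond the scatter) from compound 1 to compound 3 and a 2.1-fold higher number (0.33 log units; beyond the scatter) from compound 2 to compound 4, at least 5.4-fold (0.73 log units) apart, beyond the scatter of two such steps

Among the compounds shown here, only two groups have been compared at this position, so it remains open how an amine or a longer chain such as ethoxy would behave there. As far as these compounds go, whether plain hydrogen would do as well as fluoro is also open.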